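Ring-opened dithiol chain versus cyclic form on two cores

This account rests on a few compounds, and the source may have more. Where it says the series, first, only, none or still open, it means among the compounds named here.

Compound 1 `O=C(CCCCC1CCSS1)Nc1ccc([N+](=O)[O-])c(C(F)(F)F)c1` and compound 2 `O=C(CCCCC1CCSS1)Nc1cccc2ccccc12` carry the same amide-linked chain and differ only in the core; the difference between the two cores is not broken down here. In a functional assay on NCI-H460 cells (Homo sapiens) for inhibition, read by MTT assay, with a stated time of 24 h, tested at 0.1 ug/mL (a higher number here means more inhibition of growth at the concentration tested, a lower number less inhibition of growth), compound 1 gives 18.8%, while compound 2 gives 2.36%. Compound 3 `O=C(CCCCC(S)CCS)Nc1ccc([N+](=O)[O-])c(C(F)(F)F)c1` is compound 1 with a group of 5 heavy atoms (3 carbon, 2 sulfur; no ring) in place of a group of 5 heavy atoms (3 carbon, 2 sulfur; one five-membered non-aromatic ring with 2 hetero atoms), on a saturated chain carbon, four bonds along the chain from a carbonyl carbon. In this assay compound 3 gives 3.2%, which is a number 15.6 percentage points lower from compound 1 to compound 3 (beyond the scatter). Compound 2 and compound 3 lie within the usual scatter of each other, so no order between them is claimed; compound 1 stands beyond the scatter above both of them.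

Compound 4 `O=C(CCCCC(S)CCS)Nc1cccc2ccccc12` is the not yet measured counterpart on the core of compound 2, carrying (a group of 5 heavy atoms (3 carbon, 2 sulfur; no ring) in place of a group of 5 heavy atoms (3 carbon, 2 sulfur; one five-membered non-aromatic ring with 2 hetero atoms), on a saturated chain carbon, four bonds along the chain from a carbonyl carbon). The place of the change reads the same word for word as in the pair above, so this is the same change as from compound 1 to compound 3, here made on a core that already sits near the bottom of the range seen so far. The earlier step was a modest loss; the same change on compound 2 is expected to give a smaller step of a number 2.4 percentage points lower from compound 2 to compound 4 (within the scatter), because compound 2 starts from 2.36% and the read-out has little room left to fall at this concentration. Compound 4 is therefore expected at 0%, with a range from -9% to 9%.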

Compound 4, percent growth inhibition at one concentration: "not active" (no number reported)
The entry for compound 4 holds no number; there is nothing to compare the estimate with.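

In this assay, within the data shown here, compound 4 is recorded as "not active" without a number, so no step from compound 2 to compound 4 can be read. No evidence bears on this result. The compounds shown leave open whether 1,3-disulfanylpropyl in place of the ring-bearing group lowers growth inhibition on the core of compound 2, as it does on the core of compound 1.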